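A few compounds are considered here, and "the series" means these few. Any claim that something is new, unique, unknown or untested is made for them only; others in the source may bear on it.

Measured in a functional assay on LNCaP cells (Homo sapiens) for antiproliferative activity; on this read-out higher numbers stand for weaker inhibition and lower numbers for stronger inhibition:
- compound 1 `Cn1ncc(Cl)c1-c1cc(C(=O)N[C@@H]2CN[C@H](CCn3cncn3)C[C@H]2c2ccc(Cl)c(Cl)c2)oc1Cl`: 60 nM
- compound 2 `Cn1ncc(Cl)c1-c1cc(C(=O)N[C@@H]2CN[C@H](CCN3CCCCC3)C[C@H]2c2ccc(Cl)c(Cl)c2)oc1Cl`: 1780 nM
- compound 3 `C=CC[C@@H]1C[C@@H](c2ccc(Cl)c(Cl)c2)[C@H](NC(=O)c2cc(-c3c(Cl)cnn3C)c(Cl)o2)CN1`: 160 nM

Compound 3, at 160 nM, holds the middle of these three numbers. Compound 4 `CN(C)CC[C@@H]1C[C@@H](c2ccc(Cl)c(Cl)c2)[C@H](NC(=O)c2cc(-c3c(Cl)cnn3C)c(Cl)o2)CN1` keeps the shared core and changes one group: (dimethylamino)methyl in place of vinyl on a saturated chain carbon bound to a saturated ring carbon. In words, (dimethylamino)methyl replaces vinyl on a saturated chain carbon bound to a saturated ring carbon.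

Two measured steps at this site bear on the change. The closer precedent is the saturated amine piperidin-1-yl, with an 11-fold lower number from compound 2 to compound 3 (1.05 log units; beyond the scatter), a large step. The triazole gave a 2.7-fold higher number from compound 1 to compound 3 (0.43 log units; beyond the scatter), a modest step, and a 30-fold higher number from compound 1 to compound 2 (1.47 log units; beyond the scatter), a large one.

The dimethylamino group resembles piperidin-1-yl more than the triazole, so a clear rise is expected, though smaller than the full gap to compound 2. In this assay the expected step is a 4.4-fold higher number from compound 3 to compound 4 (0.64 log units; beyond the scatter). Compound 4 is estimated at 700 nM, with an expected range from 200 nM to 2000 nM.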

Compound 4, half-maximal inhibitory concentration: 1930 nM
The estimate for compound 4 lay 2.8-fold (0.44 log units) below the measured number; measured number inside the range.
By their numbers in this assay, from the lowest: compound 1; then compound 3; then compounds 2 and 4 (each within the scatter of the next).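

In this assay the step of a 12-fold higher number from compound 3 to compound 4 (1.08 log units; beyond the scatter) shows that a 2-(dimethylamino)ethyl chain at this place does far worse than allyl. The step of a 1.1-fold higher number from compound 2 to compound 4 (0.04 log units; within the scatter) leaves dimethylamino and piperidin-1-yl level, and the step of a 32-fold higher number from compound 1 to compound 4 (1.51 log units; beyond the scatter) puts this second saturated amine as far from the triazole as the first. Nothing measured here says why the two amines match.

Going by these compounds, whether every amine on this chain shares that high number stays open. A morpholin-4-yl group, a primary amine or a carboxylic acid at the same chain end would test it.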